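Ring nitrogen position in the pyridylmethyl imine series

The compounds below may be only part of what the source reports. "The series", "measured", "known", "first", "only" and "open" are said of these compounds alone.

Among the measured compounds shown here, compound 2 `C/C(=N\Cc1ccccn1)c1c(O)c2ccccc2oc1=O` is the only member with a number in an assay on isolated protein for inhibition of myosin-2 (Bos taurus), read by spectrophotometry, with a stated time of 24 min; a higher number here means a weaker inhibitor, a lower number a stronger inhibitor: compound 2 gives 22000 nM. Compound 1 `C/C(=N\CC1CCCCC1)c1c(O)c2ccccc2[nH]c1=O` reaches only a limit of the assay, >= 100000 nM, in this assay. Compound 3 `CCCC/N=C(\C)c1c(O)c2ccccc2[nH]c1=O` likewise sits at a limit, >= 100000 nM. For the measured compounds named here, the single step between measured compounds, a step that the two limits leave unreadable from compound 1 to compound 3, is unreadable because both ends rest at the limit of >= 100000 nM in this assay, at which 2 of the 3 values shown sit. Compound 4 `C/C(=N\Cc1cccnc1)c1c(O)c2ccccc2oc1=O` differs from compound 2 by pyridin-3-yl in place of pyridin-2-yl on a saturated chain carbon bound to a double-bonded nitrogen. Going by the values given here, no measured step touches this change, and the two limits give no size for any step, so no shift beyond the scatter is expected in this assay. Compound 4 is expected at 22000 nM, with a range from 8000 nM to 60000 nM. The step of no change at the digits printed from compound 2 to compound 4 (within the scatter) is expected to stay within the usual scatter.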

Compound 4, half-maximal inhibitory concentration: 17000 nM
The estimate for compound 4 lay 1.3-fold (0.11 log units) above the measured number, within the range that was stated.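

In this assay the series gains its first readable step (a 1.3-fold lower number from compound 2 to compound 4 (0.11 log units; within the scatter)); the earlier step cannot be read. On a saturated chain carbon bound to a double-bonded nitrogen, pyridin-3-yl in place of pyridin-2-yl therefore makes no difference beyond the scatter, so this change of ring nitrogen position leaves the number effectively unmoved. Nothing measured here accounts for this flat step. Still open, on these data alone, is whether phenyl or morpholine at this place would hold the number of compound 2 or move it. Also open, as far as these compounds go, is whether an amine added to the pyridine ring would shift the number beyond the scatter.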